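Pyrrolidin-1-yl for 4-methylpiperazin-1-yl in compound 4

The source may report more compounds than this note shows. Statements on the series, on what has been measured and on what is new or still open speak of the compounds shown alone.

Measured in a functional assay on BXPC-3 cells (Homo sapiens) for cytotoxicity, read by fluorescence, with a stated time of 48 h; a lower number here means that less compound is needed, a higher number that more compound is needed for the effect:
- compound 1 `CC(C)=CCC/C(C)=C/CC/C(C)=C/CSC[C@H](NC(=O)CCCCCN1CCCC1)C(=O)NC1CCCCC1`: 12700 nM
- compound 2 `CC(C)=CCC/C(C)=C/CC/C(C)=C/CSC[C@H](NC(=O)CCCCCN1CCN(C)CC1)C(=O)NC1CCCCCCC1`: 7500 nM
- compound 3 `CC(C)=CCC/C(C)=C/CC/C(C)=C/CSC[C@H](NC(=O)CCCCCN1CCN(C)CC1)C(=O)N1CCCCC1`: 8800 nM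

Compound 2 gives 7500 nM, which lies within the usual scatter of the values of both other compounds. Compound 4 `CC(C)=CCC/C(C)=C/CC/C(C)=C/CSC[C@H](NC(=O)CCCCCN1CCCC1)C(=O)NC1CCCCCCC1` is not yet measured. It differs from compound 2 as follows: pyrrolidin-1-yl in place of 4-methylpiperazin-1-yl on a saturated chain carbon, five bonds along the chain from a carbonyl carbon. In short, pyrrolidin-1-yl stands in place of 4-methylpiperazin-1-yl.

Within the data shown here, only one measured step is at hand, a 1.2-fold higher number from compound 2 to compound 3 (0.07 log units; within the scatter). It changes a different place, on a carbonyl carbon, so it does not test this exchange directly. It does show a change that leaves this assay within the scatter. Compound 1 already carries pyrrolidin-1-yl and gives 12700 nM, within the scatter of compound 2, although the two also differ on the carbonyl carbon. No step beyond the scatter is therefore expected, and no direction can be favoured.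

The expected step is a 1.1-fold higher number from compound 2 to compound 4 (0.05 log units; within the scatter). For compound 4 the estimated value is 8500 nM, with an expected range of 4500 nM to 16000 nM.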

Compound 4, half-maximal effective concentration: 4000 nM
For compound 4 the middle estimate is 2.1-fold (0.33 log units) above the measured one, outside the stated range (below it).
By their numbers in this assay, from the lowest: compounds 4, 2, 3 and 1 (each within the scatter of the next, the first and the last beyond it).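

On a saturated chain carbon, five bonds along the chain from a carbonyl carbon, pyrrolidin-1-yl in place of 4-methylpiperazin-1-yl now has a direct reading in this assay: a 1.9-fold lower number from compound 2 to compound 4 (0.27 log units; within the scatter), so this exchange alone does not move the number beyond the scatter. Among these compounds, the clearer step lies on the amide-type nitrogen, where, with pyrrolidin-1-yl held fixed, cyclooctyl in place of cyclohexyl gives a 3.2-fold lower number from compound 1 to compound 4 (0.50 log units; beyond the scatter), the only step beyond the scatter so far, though a modest one. The data offer no explanation for this step.

On these data alone, whether the cyclooctyl step holds with 4-methylpiperazin-1-yl on the chain remains open. Also open, as far as these compounds go, is how morpholin-4-yl or dimethylamino would read at the same chain carbon in this assay.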